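The compounds below may be only part of what the source reports. "The series", "measured", "known", "first", "only" and "open" are said of these compounds alone.

Among the compounds with values here, in a functional assay on GOTO cells (Homo sapiens) for cytotoxicity, read by MTT assay, with a stated time of 3 days (on this read-out lower numbers stand for stronger inhibition and higher numbers for weaker inhibition), compound 3 `CCNc1nc(SCc2nc3ccccc3[nH]2)nc(-c2ccccc2)c1C#N` gives 3.96 nM, the lowest of the three numbers so far. Compound 2 `N#Cc1c(Nc2ccccc2)nc(SCc2nc3ccccc3[nH]2)nc1-c1ccccc1` gives 6.41 nM, and compound 1 `N#Cc1c(Cl)nc(SCc2nc3ccccc3[nH]2)nc1-c1ccccc1` gives 8.62 nM. Within the data shown here, the steps that bear on this position of the shared core are a 2.2-fold lower number from compound 1 to compound 3 (0.34 log units; beyond the scatter) and a 1.6-fold lower number from compound 2 to compound 3 (0.21 log units; within the scatter); neither the anilino nor the ethylamino group moved the number far. Compound 4 `N#Cc1c(NNC(N)=S)nc(SCc2nc3ccccc3[nH]2)nc1-c1ccccc1` differs from compound 3 by a group of 4 heavy atoms (1 carbon, 2 nitrogen, 1 sulfur; no ring) in place of a group of 2 heavy atoms (2 carbon; no ring), on a nitrogen on an aromatic ring. Because both a 2.2-fold lower number from compound 1 to compound 3 (0.34 log units; beyond the scatter) and a 1.6-fold lower number from compound 2 to compound 3 (0.21 log units; within the scatter) were small, a large shift is not anticipated. For compound 4 the expected step is a 1.8-fold higher number from compound 3 to compound 4 (0.25 log units; within the scatter), none beyond the scatter. The estimate for compound 4 is 7 nM, with a range from 2.5 nM to 25 nM.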

Compound 4, half-maximal inhibitory concentration: 2.55 nM
Beside the measured number, compound 4's estimate is 2.7-fold (0.44 log units) above it; the range from low to high includes it.
By their numbers in this assay, from the lowest: compounds 4, 3, 2 and 1 (each within the scatter of the next, the first and the last beyond it).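

In this assay, a group with no ring that brings hydrogen-bond donors and an acceptor, in place of ethyl on the nitrogen, gives a 1.6-fold lower number from compound 3 to compound 4 (0.19 log units; within the scatter), so this position accepts it without loss. Set against the anilino group, the change gives a 2.5-fold lower number from compound 2 to compound 4 (0.40 log units; beyond the scatter), and against chloro on the aromatic carbon, it gives a 3.4-fold lower number from compound 1 to compound 4 (0.53 log units; beyond the scatter), the widest step so far. Nothing shown here accounts for these steps. As far as these compounds go, what an unsubstituted amine or a morpholine on that aromatic carbon would give remains open.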